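Fluoro for nitro at an assay limit

The compounds below may be only part of what the source reports. "The series", "measured", "known", "first", "only" and "open" are said of these compounds alone.

Compound 1 `O=C1NC(=O)N(/N=C/c2ccc(-c3ccc(Cl)cc3)o2)C1O`: > 1000 mg/kg
Compound 2 `Nc1ccc(-c2ccc(/C=N/N3C(=O)NC(=O)C3O)o2)cc1`: > 1000 mg/kg
Compound 3 `O=C1NC(=O)N(/N=C/c2ccc(-c3ccc([N+](=O)[O-])cc3)o2)C1O`: > 1000 mg/kg

In a functional assay on the whole organism for activation, with Mus musculus as the target, with a stated time of 60 min (on this read-out lower numbers stand for an effect already at smaller amounts and higher numbers for an effect only at larger amounts of compound), compound 3 gives > 1000 mg/kg, which is a limit and not a number. The entries for compound 1 and compound 2 are limits too. Compound 4 `O=C1NC(=O)N(/N=C/c2ccc(-c3ccc(F)cc3)o2)C1O` carries fluoro in place of nitro on an aromatic carbon. The nearest measured changes are a step that the two limits leave unreadable from compound 1 to compound 3 and a step that the two limits leave unreadable from compound 2 to compound 3, so neither offers a size to carry over. The firmest evidence is the limit of > 1000 mg/kg in this assay, at which 3 of the 3 values shown sit, and another result at that limit is therefore expected. The expected change in this assay is a step that the limit leaves unreadable from compound 3 to compound 4, with no direction that can be stated. The estimate for compound 4 is 1500 mg/kg, with an expected range (700 mg/kg to 3000 mg/kg).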

Compound 4, dose for half-maximal effect: 1000 mg/kg
Estimate against measurement, compound 4: 1.5-fold (0.18 log units) above; low and high end bracket the measured number.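

In this assay, within the data shown here, compound 4 gives 1000 mg/kg, the only value shown that is a number and not a limit. With fluoro in place of nitro on this aromatic carbon, para to a large group, the step is a number no higher from compound 3 to compound 4 (the limit leaves the size open). With fluoro in place of amino the step is a number no higher from compound 2 to compound 4 (the limit leaves the size open), and with fluoro in place of chloro it is a number no higher from compound 1 to compound 4 (the limit leaves the size open). None of these steps can be sized, as the other values shown are limits: the limit of > 1000 mg/kg in this assay, at which 3 of the 4 values shown sit.

From the compounds shown here alone, how far fluoro truly differs from chloro, amino or nitro stays open. So does what a methoxy group or a carboxylic acid would give at this position.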